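The source may hold more compounds than are shown below. What is called first, only, known or untested is meant among the compounds shown, and "the series" means these compounds.

Measured compounds:
Compound 1 `Nc1nc(N/N=C/c2cncs2)nc2c1ncn2[C@@H]1O[C@H](CO)[C@@H](O)[C@H]1O` gives 22 nM in an assay on CHO-K1 cells for displacement of a labelled ligand from adenosine receptor A1 (Homo sapiens), read by scintillation counting, with a stated time of 60 min; on this read-out lower numbers stand for stronger inhibition and higher numbers for weaker inhibition.
Compound 2 `CCOc1cc(/C=N/Nc2nc(N)c3ncn([C@@H]4O[C@H](CO)[C@@H](O)[C@H]4O)c3n2)ccc1O` gives 6940 nM in this assay.

Of the two numbers shown, compound 1 has the lowest; its nearest neighbour is compound 2, reached by a 320-fold higher number from compound 1 to compound 2 (2.50 log units; beyond the scatter). Within the data shown here, the only change in that step is 3-ethoxy-4-hydroxyphenyl in place of 1,3-thiazol-5-yl on a carbon with a double bond to nitrogen, and it costs a great deal.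

Compound 3 `Nc1nc(N/N=C/c2ccc(C(F)(F)F)cc2)nc2c1ncn2[C@@H]1O[C@H](CO)[C@@H](O)[C@H]1O` has not been measured in this assay. It differs from compound 1 by 4-(trifluoromethyl)phenyl in place of 1,3-thiazol-5-yl on a carbon with a double bond to nitrogen. Among the measured compounds shown here, the one step that bears on this change is a 320-fold higher number from compound 1 to compound 2 (2.50 log units; beyond the scatter), which also swapped the 1,3-thiazol-5-yl for a six-membered aromatic ring of carbon only; that step was large. The ring entering in compound 3 carries a trifluoromethyl instead of the ethoxy and hydroxy groups, so how much of that loss carries over is not settled by these two compounds alone. Compound 3 is therefore expected to give a higher number than compound 1, by roughly an 18-fold higher number from compound 1 to compound 3 (1.26 log units; beyond the scatter). For compound 3 the estimate is 400 nM, within a range of 60 nM to 3000 nM.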

Compound 3, inhibition constant: 37 nM
Compound 3: the middle estimate sits 11-fold (1.03 log units) above what was measured, outside the stated range (below it).
By their numbers in this assay, from the lowest: compounds 1 and 3 (each within the scatter of the next); then compound 2.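

In this assay, the place on a carbon with a double bond to nitrogen takes 4-(trifluoromethyl)phenyl as readily as 1,3-thiazol-5-yl, since the exchange amounts to a 1.7-fold higher number from compound 1 to compound 3 (0.23 log units; within the scatter) and so separates the two compounds by no more than repeat measurements would. The thiazolyl group and its 2 hydrogen-bond acceptors are therefore not needed for the low number, and a group of 10 heavy atoms in place of 5 is tolerated here. With the six-membered aromatic ring of carbon only kept, exchanging 3-ethoxy-4-hydroxyphenyl for 4-(trifluoromethyl)phenyl gives a 190-fold lower number from compound 2 to compound 3 (2.27 log units; beyond the scatter) and so, across these three compounds, ties the large loss to the groups on the ring of compound 2 and not to the ring type alone.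

Which of the ethoxy and hydroxy groups carries that loss stays open, as does whether a methyl, an amine or a carboxylic acid on the ring in place of trifluoromethyl would keep the number low. Nothing shown offers a measured explanation for these differences.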